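The source may report more compounds than this note shows. Statements on the series, on what has been measured and on what is new or still open speak of the compounds shown alone.

Measured so far:
Compound 1 `COc1cc2c(Oc3ccc(NC(=O)N/N=C/c4ccc(C(F)(F)F)cc4)cc3F)ccnc2cc1OCCCN1CCCCC1` — 630 nM
Compound 2 `COc1cc2c(Oc3ccc(NC(=O)N/N=C/c4ccc(Cl)cc4Cl)cc3F)ccnc2cc1OCCCN1CCCCC1` — 460 nM
Compound 3 `COc1cc2c(Oc3ccc(NC(=O)N/N=C/c4ccc(N(C)C)cc4)cc3F)ccnc2cc1OCCCN1CCCCC1` — 870 nM

All three numbers come from a functional assay on MKN-45 cells (Homo sapiens) for cytotoxicity, read by MTT assay, with a stated time of 72 h; on this read-out lower numbers stand for stronger inhibition and higher numbers for weaker inhibition. Compound 3 gives the highest number of the three, yet neither a 1.4-fold higher number from compound 1 to compound 3 (0.14 log units; within the scatter) nor a 1.9-fold higher number from compound 2 to compound 3 (0.28 log units; within the scatter) rises beyond the scatter, so the three compounds cannot be told apart by this read-out. Compound 4 `C=CCc1cccc(/C=N/NC(=O)Nc2ccc(Oc3ccnc4cc(OCCCN5CCCCC5)c(OC)cc34)c(F)c2)c1OC` keeps the shared core and differs from compound 3 in one place: 3-allyl-2-methoxyphenyl in place of 4-(dimethylamino)phenyl on a carbon with a double bond to nitrogen. Every measured step is a swap of the same kind, an exchange of the aromatic group on the carbon with a double bond to nitrogen, and each stayed within the scatter: a 1.4-fold lower number from compound 1 to compound 2 (0.14 log units; within the scatter), a 1.4-fold higher number from compound 1 to compound 3 (0.14 log units; within the scatter), a 1.9-fold higher number from compound 2 to compound 3 (0.28 log units; within the scatter). The entering group has no measured counterpart among these compounds, so nothing points to a step in either direction beyond the scatter. On that basis compound 4 is expected to give about 800 nM in this assay, with a range from 300 nM to 2200 nM. That estimate means a 1.1-fold lower number from compound 3 to compound 4 (0.04 log units; within the scatter), a step expected to stay within the scatter.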

Compound 4, half-maximal inhibitory concentration: 670 nM
The estimate for compound 4 lay 1.2-fold (0.08 log units) above the measured number; measured number inside the range.
By their numbers in this assay, from the lowest: compounds 2, 1, 4 and 3 (each within the scatter of the next).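

In this assay, going by these compounds alone, the carbon with a double bond to nitrogen also tolerates 3-allyl-2-methoxyphenyl, the first group here with a double bond outside the aromatic ring, and the result stays level with all three earlier compounds (a 1.3-fold lower number from compound 3 to compound 4 (0.11 log units; within the scatter)) and (a 1.5-fold higher number from compound 2 to compound 4 (0.16 log units; within the scatter)) and (a 1.1-fold higher number from compound 1 to compound 4 (0.03 log units; within the scatter)). Across these four compounds, then, exchanging one substituted phenyl group for another at this place has produced no step beyond the scatter, even with the larger entering group of 11 heavy atoms. Nothing available explains why these numbers stay so close.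

As far as these compounds go, all four groups at this place are phenyl rings, so it remains open whether a non-aromatic group such as cyclohexyl or a plain alkyl chain would stay level too. From the compounds shown here alone, a phenyl ring carrying a carboxylic acid or a primary amine is equally open.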